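A few compounds are considered here, and "the series" means these few. Any claim that something is new, unique, unknown or untested is made for them only; others in the source may bear on it.

In a functional assay on MGC-803 cells (Homo sapiens) for antiproliferative activity, read by MTT assay, with a stated time of 72 h (a higher number here means a weaker inhibitor, a lower number a stronger inhibitor), compound 3 `CCCSc1nc(N/N=C/c2ccc(N(C)C)cc2)c2nnn(Cc3ccccc3)c2n1` gives 13100 nM, and compound 1 `CCCSc1nc(N/N=C/c2ccccc2Cl)c2nnn(Cc3ccccc3)c2n1` gives 10900 nM; the two lie within the scatter of each other. Compound 2 `CCCSc1nc(N/N=C/c2cccs2)c2nnn(Cc3ccccc3)c2n1` reads > 64000 nM, which is a limit of the assay.

Compound 4 `CCCSc1nc(N/N=C/c2ccccc2)c2nnn(Cc3ccccc3)c2n1` follows from compound 3 with hydrogen in place of dimethylamino on an aromatic carbon, or 4-(dimethylamino)phenyl to phenyl. The nearest evidence is a 1.2-fold higher number from compound 1 to compound 3 (0.08 log units; within the scatter), an exchange between two substituted phenyl groups. The larger steps, an at least 5.8-fold higher number from compound 1 to compound 2 (0.76 log units; beyond the scatter) and an at least 4.8-fold lower number from compound 2 to compound 3 (0.68 log units; beyond the scatter), both involve thiophen-2-yl, which compound 4 lacks, so they bear on it only weakly. In this assay, the estimated step is a 1.1-fold higher number from compound 3 to compound 4 (0.06 log units; within the scatter), so no change beyond the scatter is expected. For compound 4, the estimated value is 15000 nM, with an expected range of 6000 nM to 40000 nM.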

Compound 4, half-maximal inhibitory concentration: > 64000 nM
Compound 4 was reported as a limit; the forecaster's own chance of this, stated with the estimate: 15%; at least 4.2-fold (0.63 log units) between middle value and limit.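

Taking dimethylamino off the aromatic carbon para to a large group gives an at least 4.8-fold higher number from compound 3 to compound 4 (0.68 log units; beyond the scatter), and taking chloro off gives an at least 5.8-fold higher number from compound 1 to compound 4 (0.76 log units; beyond the scatter). Among the phenyl compounds, a substituent of either kind thus goes with a readable value and the bare phenyl does not, which compound 1 and compound 3, within the scatter of each other, could not show. The step between compound 2 and compound 4 cannot be read, since both values are limits: the limit of > 64000 nM in this assay, at which 2 of the 4 values shown sit.

As far as these compounds go, compound 4 stands at a limit, so how far its value lies past it stays open. Whether a smaller group such as methoxy or fluoro at this place also gives a readable value is open too.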